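Adding an Amino Group to Two Nucleoside Cores

A few compounds are considered here, and "the series" means these few. Any claim that something is new, unique, unknown or untested is made for them only; others in the source may bear on it.

Measured so far:
compound 1, `COc1nc(N)nc2c1c(-c1ccco1)cn2[C@@H]1O[C@H](CO)[C@@H](O)[C@H]1O`: 89700 nM
compound 2, `O=c1[nH]cnc2c1c(-c1ccccc1)cn2[C@@H]1O[C@H](CO)[C@@H](O)[C@H]1O`: > 100000 nM (a limit)
compound 3, `COc1ncnc2c1c(-c1ccco1)cn2[C@@H]1O[C@H](CO)[C@@H](O)[C@H]1O`: 1700 nM

In an ADME assay on MRC5 cells (Homo sapiens), read by MTT assay, with a stated time of 72 h (on this read-out higher numbers stand for weaker inhibition and lower numbers for stronger inhibition), compound 3 gives 1700 nM and compound 1 gives 89700 nM. The change amino in place of hydrogen on an aromatic carbon produced a 53-fold higher number from compound 3 to compound 1 (1.72 log units; beyond the scatter). For compound 2 this assay reports only a limit, > 100000 nM (the limit of > 100000 nM in this assay, at which 1 of the 3 values shown sits). The difference between the cores of compound 2 and compound 3 is not broken down here. Compound 4, `Nc1nc2c(c(-c3ccccc3)cn2[C@@H]2O[C@H](CO)[C@@H](O)[C@H]2O)c(=O)[nH]1`, is not yet measured; it arises from compound 2 through (amino in place of hydrogen on an aromatic carbon), the same kind of change, the surroundings differing in that the new group sits meta to a group of 1 heavy atom rather than meta to a methoxy group (2 heavy atoms). The step from compound 2 to compound 4 is expected to be a step that the limit leaves unreadable from compound 2 to compound 4, resting on a 53-fold higher number from compound 3 to compound 1 (1.72 log units; beyond the scatter). Compound 4 is therefore expected to give about 300000 nM in this assay, most likely again reported only as a limit, somewhere between 100000 nM and 3000000 nM.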

Compound 4, half-maximal inhibitory concentration: > 100000 nM
Compound 4 ended at the assay's limit; the forecaster's own chance of this, stated with the estimate: 90%; the middle value lies beyond the limit too.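

Compound 2 and compound 4 both give a limit rather than a number, so the step between them cannot be read: the limit of > 100000 nM in this assay, at which 2 of the 4 values shown sit.

As far as these compounds go, whether the amino group changes the number on the core of compound 2 as it does on the core of compound 3 remains open.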